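Carbamate series, cathepsin S: amide ring size

The compounds below may be only part of what the source reports. "The series", "measured", "known", "first", "only" and "open" are said of these compounds alone.

Measured compounds:
Compound 1 `C[C@@H](CN1CC(C)(C)c2cc(F)ccc21)NC(=O)O[C@@H](CC1CCCCC1)C(=O)N(C)C` — 227 nM
Compound 2 `C[C@@H](CN1CC(C)(C)c2cc(F)ccc21)NC(=O)O[C@@H](CC1CCCCC1)C(=O)N1CCCC1` — 56 nM

Among the compounds with values here, compound 2 holds the lower of the two numbers so far in an assay on isolated protein for inhibition of cathepsin S (Homo sapiens); a lower number here means a stronger inhibitor, a higher number a weaker inhibitor; the only neighbour is compound 1, and the step of a 4.1-fold lower number from compound 1 to compound 2 (0.61 log units; beyond the scatter) separates them. Within the data shown here, that step is the single measured change, and it concerns the same position as the one considered next: the amide on the carbonyl carbon.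

Compound 3 `C[C@@H](CN1CC(C)(C)c2cc(F)ccc21)NC(=O)O[C@@H](CC1CCCCC1)C(=O)N1CCCCC1` differs from compound 2 by piperidin-1-yl in place of pyrrolidin-1-yl on a carbonyl carbon. Among the measured compounds shown here, the one measured step that bears on it, a 4.1-fold lower number from compound 1 to compound 2 (0.61 log units; beyond the scatter), showed that enlarging the amide substituent at this position, from dimethylamino to pyrrolidin-1-yl, gave a modest gain in this assay. Adding one more ring carbon is a smaller change than the one already measured, so a smaller step is expected, in either direction, most likely within or just beyond the scatter, with a slight lean toward a lower number.

For compound 3 the expected step is a 1.2-fold lower number from compound 2 to compound 3 (0.09 log units; within the scatter). The estimate for compound 3 in this assay is 45 nM, with a range from 15 nM to 150 nM.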

Compound 3, inhibition constant: 39 nM
Estimate against measurement, compound 3: 1.2-fold (0.06 log units) above, within the range that was stated.
By their numbers in this assay, from the lowest: compounds 3 and 2 (each within the scatter of the next); then compound 1.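

In this assay, within the data shown here, piperidin-1-yl in place of pyrrolidin-1-yl on the carbonyl carbon gives a step that stays within the scatter (a 1.4-fold lower number from compound 2 to compound 3 (0.16 log units; within the scatter)), so compounds 2 and 3 cannot be told apart here, a point that could not be read while only one ring amide was at hand. Set against the open-chain dimethylamino amide, piperidin-1-yl gives a step beyond the scatter (a 5.8-fold lower number from compound 1 to compound 3 (0.76 log units; beyond the scatter)), so compound 1 now stands apart from both ring amides, and the modest gain first seen with pyrrolidin-1-yl holds with the six-membered ring as well. Nothing at hand explains why the two ring amides sit together or why the dimethylamino amide stands apart from them.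

Still open, as far as these compounds go, is whether the tolerance for ring size extends further, to the seven-membered azepan-1-yl, or to a ring carrying a second hetero atom, such as morpholin-4-yl. An open-chain diethylamino amide would also show whether the ring itself matters at this position or whether the added carbons alone account for the step from dimethylamino.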